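A few compounds are considered here, and "the series" means these few. Any claim that something is new, unique, unknown or untested is made for them only; others in the source may bear on it.

Compound 1 `NS(=O)(=O)c1ccc(NC(=O)NCc2ccncc2)cc1` stands at the top of the three numbers gathered so far: in an assay on isolated protein for activation of Nicotinamide phosphoribosyltransferase (Homo sapiens) (on this read-out lower numbers stand for an effect already at smaller amounts and higher numbers for an effect only at larger amounts of compound), compound 1 gives 14300 nM. Both of its companions carry an ethyl ester in place of the sulfonamide and a different five-membered heteroaryl on the urea-bound methylene. In this assay compound 2 `CCOC(=O)c1ccc(NC(=O)NCc2cn[nH]c2)cc1` gives 1850 nM, and compound 3 `CCOC(=O)c1ccc(NC(=O)NCc2cnco2)cc1` gives 6900 nM. For the measured compounds named here, the only step between neighbours that differ in one place, a 3.7-fold higher number from compound 2 to compound 3 (0.57 log units; beyond the scatter), concerns that heteroaryl and not the sulfonyl end. Compound 1 differs from compound 2 and from compound 3 in two places at once, so its position is told only by its own number, which lies beyond the scatter above both of them.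

Compound 4 `CCN(C1CCCC1)S(=O)(=O)c1ccc(NC(=O)NCc2ccncc2)cc1` keeps the pyridylmethyl urea of compound 1 and changes the sulfonyl substituent: cyclopentyl(ethyl)amino in place of amino on a sulfonyl sulfur. Going by the values given here, no measured step touches this position, so nothing seen here tells the size or direction of the effect. A modest lowering of the number is nonetheless estimated, held within a wide range: the expected step is a 4.8-fold lower number from compound 1 to compound 4 (0.68 log units; beyond the scatter). Compound 4 is therefore expected to give about 3000 nM, between 500 nM and 15000 nM, in this assay.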

Compound 4, half-maximal effective concentration: 60 nM
Compound 4: middle estimate off by 50-fold (1.70 log units), on the high side, and the stated range ends above it.
By their numbers in this assay, from the lowest: compound 4; then compound 2; then compound 3; then compound 1.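

In this assay, for the compounds shown here, the substituent on the sulfonyl sulfur proves to be a position of large effect: cyclopentyl(ethyl)amino in place of amino gives a 240-fold lower number from compound 1 to compound 4 (2.38 log units; beyond the scatter), well beyond the only earlier step, a 3.7-fold higher number from compound 2 to compound 3 (0.57 log units; beyond the scatter), which concerned the heteroaryl on the methylene. With the pyridylmethyl urea kept, this pair shows that the amino group is not needed for activity here and that a much larger substituent on the sulfonyl sulfur, carrying a cyclopentyl ring, goes with a far lower number rather than a higher one. Nothing available explains why this step is so large.

As far as these compounds go, the change brings in the ethyl group and the cyclopentyl ring together, so the share of each in the step stays open; a sulfonamide nitrogen with ethyl alone or cyclopentyl alone, or a dimethylamino, piperidine or morpholine group on the sulfonyl sulfur, would begin to separate them. From the compounds shown here alone, it also stays open whether cyclopentyl(ethyl)amino would give a step of similar size with a 1H-pyrazol-4-yl or 1,3-oxazol-5-yl group on the methylene in place of the pyridine.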